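Chalcone series tested against human 5-lipoxygenase: a fourth methoxy

A few compounds are considered here, and "the series" means these few. Any claim that something is new, unique, unknown or untested is made for them only; others in the source may bear on it.

Compound 1 `COc1ccc(/C=C/C(=O)c2ccc(OCC=C(C)C)cc2O)cc1` gives > 100000 nM in an assay on isolated protein for inhibition of Polyunsaturated fatty acid 5-lipoxygenase (Homo sapiens) (on this read-out higher numbers stand for weaker inhibition and lower numbers for stronger inhibition), which is a limit of the assay.
Compound 2 `COc1ccc(/C=C/C(=O)c2ccc(OCC=C(C)C)cc2O)c(OC)c1OC` gives > 100000 nM in this assay, again a limit.
Compound 3 `COc1ccc(/C=C/C(=O)c2ccc(OCC=C(C)C)cc2O)cc1OC` gives > 100000 nM in this assay, also a limit.

Compound 3 therefore stands at the same limit as the other two measured compounds; none of them returns a number. The step that the two limits leave unreadable from compound 1 to compound 3 and the step that the two limits leave unreadable from compound 2 to compound 3 are both unreadable, since both ends lie at the limit. This is the whole of the evidence: the limit of > 100000 nM in this assay, at which 3 of the 3 values shown sit.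

Compound 4 `COc1cc(/C=C/C(=O)c2ccc(OCC=C(C)C)cc2O)cc(OC)c1OC` differs from compound 3 by methoxy in place of hydrogen on an aromatic carbon. Going by the values given here, no measured step with a readable size bears on this change, and every measured compound, including compound 3, sits at the limit. Compound 4 is therefore expected to give an estimate of 150000 nM in this assay. The estimated range for compound 4 runs from 50000 nM to 500000 nM. The expected step that the limit leaves unreadable from compound 3 to compound 4 cannot be judged against any readable measured step, and a further limit rather than a number is the expected outcome for compound 4.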

Compound 4, half-maximal inhibitory concentration: > 100000 nM
Compound 4 gave a limit, no number; the forecaster's own chance of this, stated with the estimate: 85%; the middle value does not contradict the limit.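

Compound 4 gives > 100000 nM in this assay, which is a limit of the assay. Going by these compounds alone, with limits at both ends, no step from compound 3 to compound 4 can be read. The compounds shown leave open whether adding or removing a methoxy changes inhibition at all, because they all share a single result: the limit of > 100000 nM in this assay, at which 4 of the 4 values shown sit.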